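The compounds below may be only part of what the source reports. "The series", "measured", "known", "first", "only" and "open" are said of these compounds alone.

Measured compounds:
- compound 1, `CCN1CCc2nc(C#Cc3ccccc3)sc2C1`, > 10000 nM
- compound 2, `C(#Cc1nc2c(s1)CN(C1CCCCC1)CC2)c1ccccc1`, > 10000 nM
- compound 3, `O=C(C1CCCCC1)N1CCc2nc(C#Cc3ccccc3)sc2C1`, 167 nM

Among the measured compounds shown here, in an assay on HEK293 cells for positive allosteric modulation of metabotropic glutamate receptor 5 (Homo sapiens), read by FLIPR, with a stated time of 1 h (on this read-out lower numbers stand for an effect already at smaller amounts and higher numbers for an effect only at larger amounts of compound), compound 3 gives 167 nM, the only actual number among the three. For compound 1 the value > 10000 nM is a limit of the assay, not a number. For compound 2 the value > 10000 nM is likewise a limit. The step that the two limits leave unreadable from compound 1 to compound 2 cannot be read because of the limit of > 10000 nM in this assay, at which 2 of the 3 values shown sit. The steps of an at least 59-fold lower number from compound 1 to compound 3 (1.77 log units; beyond the scatter) and an at least 59-fold lower number from compound 2 to compound 3 (1.77 log units; beyond the scatter) both show that placing a carbonyl-bearing group on the amine nitrogen in the ring brings the number into view.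

Compound 4, `O=C(N1CCC(F)CC1)N1CCc2nc(C#Cc3ccccc3)sc2C1`, keeps that carbonyl and changes only what sits on it: 4-fluoropiperidin-1-yl in place of cyclohexyl on a carbonyl carbon. For the measured compounds named here, none of the measured steps touches this position; all of them concern the group on the ring nitrogen itself, which here stays as in compound 3. Going by the values given here, there is therefore no measured step that predicts a shift in this assay, and the expectation is a step of a 1.5-fold higher number from compound 3 to compound 4 (0.18 log units; within the scatter), within the usual scatter. Compound 4 is estimated at 250 nM, in a range from 70 nM to 900 nM.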

Compound 4, half-maximal effective concentration: 74 nM
Estimate against measurement, compound 4: 3.4-fold (0.53 log units) above; the range from low to high includes it.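

The group on the carbonyl carbon turns out to matter on its own: with the amide-type nitrogen in the ring and the rest of the molecule unchanged, 4-fluoropiperidin-1-yl in place of cyclohexyl gives a 2.3-fold lower number from compound 3 to compound 4 (0.35 log units; beyond the scatter) in this assay, a modest step. Among the compounds shown here, this is the first step with a real number at both ends, so its size can be stated exactly rather than only bounded by a limit of the assay. It also shows that this position does not depend on a ring of carbon only, since a six-membered ring holding a nitrogen and carrying a fluorine keeps a measurable effect and lowers the number a little further.

The swap brings in the ring nitrogen and the fluorine together, so the compounds shown cannot say which of the two accounts for the step; plain piperidin-1-yl would separate them, and a morpholin-4-yl ring, an open butyl chain or a carboxylic acid on the same carbonyl remain unknown here. Nothing among the data shown gives a reason for this step.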